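Cyano to dimethylamino on the sulfonamide series

The source may hold more compounds than are shown below. What is called first, only, known or untested is meant among the compounds shown, and "the series" means these compounds.

Measured compounds, with lipophilicity:
compound 1 `CCc1ccc(N(CC(C)C)S(=O)(=O)c2ccc3cc(OCC4CCOCC4)c(C(=O)O)cc3c2)cc1` 1.77
compound 2 `CC(C)CN(c1ccc(C#N)cc1)S(=O)(=O)c1ccc2c(c1)C(=O)CC(C1CCOCC1)O2` 3.16
compound 3 `CCc1ccc(N(CC(C)C)S(=O)(=O)c2ccc3oc(C4CCOCC4)cc(=O)c3c2)cc1` 4.5

All three values come from a physicochemical assay for lipophilicity, at pH 7.4; on this read-out higher numbers stand for higher lipophilicity and lower numbers for lower lipophilicity. Compound 2 stands second highest of the three numbers: compound 3 lies higher, beyond the scatter, and compound 1 lies lower, also beyond the scatter. For the measured compounds named here, no two of the measured compounds differ in a single place, so no measured step within the set describes any one change on its own.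

Compound 4 `CC(C)CN(c1ccc(N(C)C)cc1)S(=O)(=O)c1ccc2c(c1)C(=O)CC(C1CCOCC1)O2` keeps the core of compound 2 and differs from it only by dimethylamino in place of cyano on an aromatic carbon.

Going by the values given here, with no comparable step among the measured compounds, the expectation for compound 4 rests on the value of compound 2 as its starting point. The step from compound 2 to compound 4 is expected to be upward and beyond the scatter, about a number 0.54 log units higher from compound 2 to compound 4 (beyond the scatter). For compound 4 in this assay the estimate is 3.7, with a range from 3.2 to 4.2.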

Compound 4, distribution coefficient: 3.6
Beside the measured number, compound 4's estimate is 0.10 log units above it, and the stated range covers the measured number.
By their numbers in this assay, from the lowest: compound 1; then compound 2; then compound 4; then compound 3.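

Reading 4-cyanophenyl to 4-(dimethylamino)phenyl in this assay gives a number 0.44 log units higher from compound 2 to compound 4 (beyond the scatter) and is the first change in the series that can be read on its own. The position, on an aromatic carbon para to a large group, is therefore not silent on this read-out: exchanging one group without a ring or net charge for another, with the rest of compound 2 unchanged, moves the number beyond the scatter. Nothing measured here bears on why the number moves.

One step at one position gives no trend: a primary amine, a methoxy group or a carboxylic acid in the same place could fall on either side of compound 2 and compound 4. From the compounds shown here alone, whether the same change gives a similar step on the core of compound 3 also stays open.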